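This account rests on a few compounds, and the source may have more. Where it says the series, first, only, none or still open, it means among the compounds named here.

Measured compounds:

compound 1 `O=C(CCCCCCCCCCCc1ccccc1)CC(=O)N[C@H]1CCOC1=O` — 4000 nM
compound 2 `O=C(CCCCCc1ccccc1)CC(=O)N[C@H]1CCOC1=O` — 9000 nM
compound 3 `O=C(CCCCCCc1ccccc1)CC(=O)N[C@H]1CCOC1=O` — 9000 nM

All three were tested in a functional assay on PC-3 cells (Homo sapiens) for cytotoxicity, read by sulforhodamine B assay, with a stated time of 5 days; on this read-out lower numbers stand for stronger inhibition and higher numbers for weaker inhibition. Compound 1 gives the lowest number of the three, and its gap to compound 2 and to compound 3 lies beyond the usual scatter. Compound 2 and compound 3 give numbers that cannot be told apart.

The pair compound 3 and compound 2 shows one structural change: phenyl in place of benzyl on a saturated chain carbon, five bonds along the chain from a carbonyl carbon. In this assay that change made a step of no change at the digits printed from compound 3 to compound 2 (within the scatter). In plain terms, cutting the chain between the carbonyl and the aromatic ring shorter by one carbon left the readout where it was.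

Compound 4 `O=C(CCCCCCCCCCc1ccccc1)CC(=O)N[C@H]1CCOC1=O` has not been measured. It stands to compound 1 as compound 2 stands to compound 3: phenyl in place of benzyl on a saturated chain carbon, ten or more bonds along the chain from a carbonyl carbon. The place is not the same, as the two differences themselves show, so this is the same kind of change rather than the same change. How the core of compound 1 differs from the core of compound 3 is not broken down here.

Because the earlier step was no change at the digits printed from compound 3 to compound 2 (within the scatter), the step from compound 1 to compound 4 is expected to be small as well, a 1.1-fold higher number from compound 1 to compound 4 (0.05 log units; within the scatter). For compound 4 in this assay the estimate is 4500 nM, with a range from 2000 nM to 10000 nM.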

Compound 4, half-maximal inhibitory concentration: 2000 nM
For compound 4 the middle estimate is 2.3-fold (0.35 log units) above the measured one; measured number inside the range.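

The change from benzyl to phenyl can now be read on two cores in this assay, and the two readings agree: the same change on two cores in this assay, no change at the digits printed (within the scatter) from compound 3 to compound 2 and a 2.0-fold lower number (0.30 log units; within the scatter) from compound 1 to compound 4, 2.0-fold (0.30 log units) apart, within the scatter of two such steps The new step, a 2.0-fold lower number from compound 1 to compound 4 (0.30 log units; within the scatter), is no larger than ordinary variation between repeated measurements, so in this small set the change leaves the readout effectively in place on the core of compound 1, as it does on the core of compound 3. This is only a comparison of two pairs: it does not prove that the change has no effect at all, since a small real effect could hide within the scatter, and it does not show that the result would hold on any other core or explain why the two steps agree.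

From the compounds shown here alone, all four compounds end their chain in an unsubstituted phenyl, so it remains open how the readout would respond to a chain ending in an amine or a carboxylic acid, or to a fluorine on the phenyl ring. Going by these compounds, a longer chain than that of compound 1 also remains open, as does whether the same agreement would appear in a different cell line.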